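Quinolin-8-yl ether series: cytotoxicity notes ahead of compound 4

The source may report more compounds than this note shows. Statements on the series, on what has been measured and on what is new or still open speak of the compounds shown alone.

Measured so far in an ADME assay on SNB-19 cells (Homo sapiens) for cytotoxicity, read by MTT assay, with a stated time of 24 h; on this read-out lower numbers stand for higher toxicity in this test and higher numbers for lower toxicity in this test:
Compound 1 `C=C1CC[C@@H]2[C@](C)(COC(C)=O)[C@H](O)CC[C@@]2(C)[C@@H]1C/C=C1/C(=O)OC[C@@H]1Oc1c(Cl)cc(Cl)c2cccnc12` gives 39300 nM.
Compound 3 `C=C1CC[C@@H]2[C@](C)(COC(C)=O)[C@H](O)CC[C@@]2(C)[C@@H]1C/C=C1/C(=O)OC[C@@H]1Oc1cccc2ccc(C)nc12` gives 65900 nM.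
Compound 2 `C=C1CC[C@@H]2[C@](C)(CO)[C@H](O)CC[C@@]2(C)[C@@H]1C/C=C1/C(=O)OC[C@@H]1Oc1cccc2ccc(C)nc12` reaches only a limit of this assay, > 100000 nM.

Compound 2 thus stands at the limit of > 100000 nM in this assay, at which 1 of the 3 values shown sits, and its step of an at least 1.5-fold lower number from compound 2 to compound 3 (0.18 log units; that floor lies within the scatter) carries a floor that lies within the scatter. Compound 4 `C=C1CC[C@@H]2[C@](C)(CO)[C@H](O)CC[C@@]2(C)[C@@H]1C/C=C1/C(=O)OC[C@@H]1Oc1c(Cl)cc(Cl)c2cccnc12` differs from compound 2 by 5,7-dichloroquinolin-8-yl in place of 2-methylquinolin-8-yl on an oxygen on a saturated carbon. The same exchange has been measured once, in the reverse direction, as a 1.7-fold higher number from compound 1 to compound 3 (0.22 log units; within the scatter); read forward it points to no change beyond the scatter, if anything a somewhat lower number. Compound 4 is therefore expected near 70000 nM, within 35000 nM to 140000 nM, an estimated step of an at least 1.4-fold lower number from compound 2 to compound 4 (0.15 log units; that floor lies within the scatter).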

Compound 4, half-maximal cytotoxic concentration: > 100000 nM
Compound 4 was reported as a limit; the forecaster's own chance of this, stated with the estimate: 35%; middle value at least 1.4-fold (0.15 log units) away from the limit.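

In this assay compound 4 sits at a limit, > 100000 nM, so the exchange of 2-methylquinolin-8-yl for 5,7-dichloroquinolin-8-yl cannot be read against compound 2. Hydrogen in place of acetyl on the oxygen gives an at least 2.5-fold higher number from compound 1 to compound 4 (0.40 log units; beyond the scatter), a reading beyond the scatter that the earlier pair of compounds 2 and 3 did not give. Whether this change is equal with both quinolin-8-yl groups stays unsettled: the same change on two cores in this assay, an at least 1.5-fold lower number (0.18 log units; that floor lies within the scatter) from compound 2 to compound 3 and an at least 2.5-fold lower number (0.40 log units; beyond the scatter) from compound 4 to compound 1; the limit leaves it open whether they differ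

As far as these compounds go, the true position of compounds 2 and 4 in this assay stays open: the limit of > 100000 nM in this assay, at which 2 of the 4 values shown sit. Also open is what a longer chain in place of the acetyl would do to the number.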